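This account rests on a few compounds, and the source may have more. Where it says the series, first, only, none or still open, it means among the compounds named here.

Series so far in a functional assay on HepG2 cells (Homo sapiens) for inhibition, read by MTT assay, with a stated time of 72 h; on this read-out lower numbers stand for stronger inhibition and higher numbers for weaker inhibition:
compound 1 (`COc1ccc(-c2nnc(SCCCN3CCN(c4nc5ccccc5o4)CC3)o2)cc1`) gives 66100 nM
compound 2 (`Brc1ccc(-c2nnc(SCCCN3CCN(c4nc5ccccc5o4)CC3)o2)cc1`) gives 67500 nM
compound 3 (`O=C(NCc1nnc(SCCCN2CCN(c3nc4ccccc4o3)CC2)o1)c1ccccc1`) gives 88900 nM

Compound 1 stands level with the other two compounds, and no order can be drawn among the three. The measured steps are a 1.0-fold higher number from compound 1 to compound 2 (0.01 log units; within the scatter) and a 1.3-fold higher number from compound 1 to compound 3 (0.13 log units; within the scatter), and the remaining one is a 1.3-fold higher number from compound 2 to compound 3 (0.12 log units; within the scatter). All three lie within the scatter.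

The next compound is compound 4 (`COc1ccc(-c2nnc(SCCCN3CCN(c4nc5ccccc5s4)CC3)o2)cc1`). It keeps the 4-methoxyphenyl group of compound 1 and carries 1,3-benzothiazol-2-yl in place of 1,3-benzoxazol-2-yl on an amine nitrogen in a ring.

Among the measured compounds shown here, no measured step touches this group, so the data hold no direct precedent for the change. All three steps exchange the other substituent, and they bear on the change only as a sign of how flat these three compounds are. The smallest, a 1.0-fold higher number from compound 1 to compound 2 (0.01 log units; within the scatter), and the largest, a 1.3-fold higher number from compound 1 to compound 3 (0.13 log units; within the scatter), both stay within the scatter.

In this assay, the expected step is none beyond the scatter (a 1.0-fold lower number from compound 1 to compound 4 (0.00 log units; within the scatter)), with no direction expected. The range is kept wide since the exchanged group has not been varied before. The estimate for compound 4 is 66000 nM, within an expected range of 30000 nM to 130000 nM.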

Compound 4, half-maximal inhibitory concentration: 134000 nM
For compound 4 the middle estimate is 2.0-fold (0.31 log units) below the measured one, and the stated range ends below it.
By their numbers in this assay, from the lowest: compounds 1, 2, 3 and 4 (each within the scatter of the next, the first and the last beyond it).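

In this assay, 1,3-benzothiazol-2-yl in place of 1,3-benzoxazol-2-yl on the amine nitrogen in a ring gives a 2.0-fold higher number from compound 1 to compound 4 (0.31 log units; beyond the scatter), a modest step but the first in the series beyond the scatter. This position therefore shows a response, towards weaker inhibition, whereas the exchanges of the other substituent among compounds 1, 2 and 3 all stayed within the scatter; the two groups differ only in sulfur for oxygen, with the same counts of heavy atoms, hydrogen-bond donors and hydrogen-bond acceptors. No supporting data on hand bear on the origin of this step, so it stands as an observation on a single matched pair.

From the compounds shown here alone, it remains open whether the same exchange produces a step of similar size and direction when the 4-methoxyphenyl group is replaced by 4-bromophenyl or benzamidomethyl. Also open, going by these compounds, is how a 1H-benzimidazol-2-yl or a plain phenyl group on the same amine nitrogen would compare with 1,3-benzoxazol-2-yl, which would show whether the response at this position extends beyond the sulfur-for-oxygen exchange.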